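The source may report more compounds than this note shows. Statements on the series, on what has been measured and on what is new or still open speak of the compounds shown alone.

Measured so far:
compound 1 `O=S(=O)(Nc1ccc(-c2nc3ccccc3o2)cc1)c1cccc(O)c1` — > 100000 nM
compound 2 `O=S(=O)(Nc1ccc2oc(-c3ccccc3)nc2c1)c1ccc(F)c(C(F)(F)F)c1` — > 100000 nM
compound 3 `O=S(=O)(Nc1ccc2oc(-c3ccccc3)nc2c1)c1ccccc1F` — 72000 nM

In an ADME assay on HEK293 cells (Homo sapiens) for cytotoxicity, read by resazurin assay, with a stated time of 48 h (on this read-out lower numbers stand for higher toxicity in this test and higher numbers for lower toxicity in this test), compound 1 gives only a limit, > 100000 nM. Compound 2 also sits at a limit, > 100000 nM. Compound 3 alone gives a number, 72000 nM. Compound 1 therefore stands at the limit of > 100000 nM in this assay, at which 2 of the 3 values shown sit, so no exact number is known for it, only that it is no more toxic than that point.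

Compound 4 `COc1ccc(S(=O)(=O)Nc2ccc(-c3nc4ccccc4o3)cc2)cc1` differs from compound 1 in one place: 4-methoxyphenyl in place of 3-hydroxyphenyl on a sulfonyl sulfur. Going by the values given here, no pair of measured compounds shows a change of this kind, so there is no measured step to lean on. In this assay I expect no step beyond the usual scatter, in either direction. Compound 4 is expected to give 150000 nM, within 60000 nM to 400000 nM. The expected step that the limit leaves unreadable from compound 1 to compound 4 is within the scatter.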

Compound 4, half-maximal cytotoxic concentration: > 100000 nM
Compound 4 ended at the assay's limit; the forecaster's own chance of this, stated with the estimate: 70%; the middle value does not contradict the limit.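

Going by these compounds alone, compound 1 and compound 4 each stop at a limit rather than a number, so no step between them can be read: the limit of > 100000 nM in this assay, at which 3 of the 4 values shown sit. On these data alone, it stays open whether 4-methoxyphenyl in place of 3-hydroxyphenyl changes the result in this assay at all.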